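Cytotoxicity notes on the amine swap toward compound 4

A few compounds are considered here, and "the series" means these few. Any claim that something is new, unique, unknown or untested is made for them only; others in the source may bear on it.

Three measured compounds share one core and differ only in the group on an aromatic carbon. Compound 1 `Cc1ccc2c(NCc3ccc(NC(=O)C4CCN(Cc5ccccc5)CC4)cc3)nc(N3CCC3)nc2c1` carries azetidin-1-yl there. In a functional assay on SV5A8 cells (Homo sapiens) for cytotoxicity (on this read-out higher numbers stand for weaker inhibition and lower numbers for stronger inhibition), compound 1 reaches only the limit > 8500 nM. Compound 2 `Cc1ccc2c(NCc3ccc(NC(=O)C4CCN(Cc5ccccc5)CC4)cc3)nc(N3CCC(N4CCCC4)CC3)nc2c1` carries 4-(pyrrolidin-1-yl)piperidin-1-yl at that carbon. In this assay compound 2 again reaches only the limit > 8090 nM. Compound 3 `Cc1ccc2c(NCc3ccc(NC(=O)C4CCN(Cc5ccccc5)CC4)cc3)nc(N3CCNC(CCO)C3)nc2c1` carries 3-(2-hydroxyethyl)piperazin-1-yl. In this assay compound 3 likewise shows only the limit > 8420 nM. Compound 3 therefore stands at a limit, and the two further values shown are limits as well. The steps a step that the two limits leave unreadable from compound 1 to compound 2, a step that the two limits leave unreadable from compound 1 to compound 3 and a step that the two limits leave unreadable from compound 2 to compound 3 stay unreadable because of the limit of > 8090 nM in this assay, at which 1 of the 3 values shown sits, the limit of > 8420 nM in this assay, at which 1 of the 3 values shown sits, and the limit of > 8500 nM in this assay, at which 1 of the 3 values shown sits, bound every end of them.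

Compound 4 `Cc1ccc2c(NCc3ccc(NC(=O)C4CCN(Cc5ccccc5)CC4)cc3)nc(N(C)CCN(C)C)nc2c1` is the next member: (2-(dimethylamino)ethyl)(methyl)amino in place of 3-(2-hydroxyethyl)piperazin-1-yl on an aromatic carbon. All three measured steps bear on this change, yet none has a readable size, so they give neither a direction nor a magnitude beyond the scatter in this assay. The expectation is that compound 4, like the three measured compounds, ends at a limit in this assay. Compound 4 is expected to give 9000 nM, with a range from 3000 nM to 30000 nM. The expected step is accordingly a step that the limit leaves unreadable from compound 3 to compound 4, a change not read as real.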

Compound 4, half-maximal inhibitory concentration: > 8830 nM
Compound 4: only a limit was reported; the forecaster's own chance of this, stated with the estimate: 80%; the middle value lies beyond the limit too.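

In this assay compound 4 gives > 8830 nM, a limit and not a number. No step from compound 1, compound 2 or compound 3 to compound 4 can be read, as all four values are limits: the limit of > 8830 nM in this assay, at which 1 of the 4 values shown sits.

The compounds shown leave open whether any of these four groups on the shared core changes the cytotoxicity read-out, and by how much.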